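Cyano in place of methoxy on the shared core

The compounds below may be only part of what the source reports. "The series", "measured", "known", "first", "only" and "open" are said of these compounds alone.

In a physicochemical assay for lipophilicity, using the shake flask method, measured as octanol-water partition, with a stated time of 30 min, at pH 7.4 (on this read-out higher numbers stand for higher lipophilicity and lower numbers for lower lipophilicity), compound 3 `COc1nn(-c2ccccn2)c2cc(-c3ccc(CCC(=O)O)cc3)ccc12` gives 3.3, level with compound 2 `Cc1nn(-c2ccccn2)c2cc(-c3ccc(CCC(=O)O)cc3Cl)ccc12` at 3.3, while compound 1 `COc1cc(CCC(=O)O)ccc1-c1ccc2c(C)nn(-c3ccccn3)c2c1` gives 2.4. Compound 4 `N#Cc1nn(-c2ccccn2)c2cc(-c3ccc(CCC(=O)O)cc3)ccc12` carries cyano in place of methoxy on an aromatic carbon. Going by the values given here, no measured compound carries cyano. Among the compounds with values here, the only measured step that removes a methoxy is a number 0.90 log units higher from compound 1 to compound 2 (beyond the scatter), modest and beyond the scatter. It brings in chloro, so it offers a scale of size and not a direction. A smaller, downward step in this assay is expected, though a change within the scatter remains possible. The expected step is a number 0.40 log units lower from compound 3 to compound 4 (beyond the scatter). Compound 4 is estimated at 2.9, with a range of 2.4 to 3.4.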

Compound 4, distribution coefficient: 3
Compound 4: the middle estimate sits 0.10 log units below what was measured; the range from low to high includes it.
By their numbers in this assay, from the lowest: compound 1; then compounds 4, 2 and 3 (each within the scatter of the next).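

On the aromatic carbon next to the ring nitrogen, cyano in place of methoxy gives a number 0.30 log units lower from compound 3 to compound 4 (within the scatter) in this assay. Methoxy and cyano match in their counts of heavy atoms and hydrogen-bond acceptors, and this read-out does not separate them here, whereas the methoxy exchange elsewhere on the series gives a number 0.90 log units higher from compound 1 to compound 2 (beyond the scatter). No supporting evidence bears on why this exchange reads as it does.

From the compounds shown here alone, whether an amine or a longer alkyl chain on this carbon would shift the value beyond the scatter remains open.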